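A few compounds are considered here, and "the series" means these few. Any claim that something is new, unique, unknown or untested is made for them only; others in the source may bear on it.

Working notes on the series. Going by the values given here, compound 1 `O=C(NC(=S)NNc1ncnc2ccccc12)c1ccccc1F` in a functional assay on CNE-2 cells (Homo sapiens) for cytotoxicity, read by MTT assay, with a stated time of 72 h (a higher number here means a weaker inhibitor, a lower number a stronger inhibitor), gives 4610 nM, the lowest of the two numbers measured so far. Compound 2 `COc1cc2ncnc(NNC(=S)NC(=O)c3ccc(F)cc3)c2cc1OC` differs from compound 1 in more than one place; in this assay compound 2 gives 16100 nM, a higher number than compound 1 by a gap that lies beyond the usual scatter. Among the compounds with values here, no pair of measured compounds differs in a single place, so no step can be read directly from the measured values.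

Compound 3 `O=C(NC(=S)NNc1ncnc2ccccc12)c1cccc(Cl)c1` keeps the core of compound 1 and changes only the group on the carbonyl carbon: 3-chlorophenyl in place of 2-fluorophenyl on a carbonyl carbon. Within the data shown here, with no comparable step on record, the expected step from compound 1 to compound 3 is a 1.2-fold lower number from compound 1 to compound 3 (0.08 log units; within the scatter), most likely no larger than the scatter, with a slight lean toward a lower number. Compound 3 in this assay is estimated at 3800 nM, within a range from 1400 nM to 11000 nM.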

Compound 3, half-maximal inhibitory concentration: 2920 nM
Compound 3: middle estimate off by 1.3-fold (0.11 log units), on the high side, within the range that was stated.
By their numbers in this assay, from the lowest: compounds 3 and 1 (each within the scatter of the next); then compound 2.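

In this assay, the series now has its first single-place step, a 1.6-fold lower number from compound 1 to compound 3 (0.20 log units; within the scatter), and it lies within the scatter. On a carbonyl carbon whose other neighbour is an amide-type nitrogen, 3-chlorophenyl and 2-fluorophenyl therefore cannot be told apart in this read-out while the core of compound 1 is held fixed. No measurement on hand offers an explanation for this result.

This single step exchanges both the halogen and the name-position of the substituent on the phenyl group, so the compounds shown cannot separate those two parts of the change. Also open, from the compounds shown here alone, is whether this position stays equally indifferent when the phenyl group gives way to a longer alkyl chain or carries an amine or a carboxylic acid.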